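Acetyl to benzyl on the shared flavone core

The source may hold more compounds than are shown below. What is called first, only, known or untested is meant among the compounds shown, and "the series" means these compounds.

Compound 1 `CC(=O)Oc1c(O)cc2oc(-c3ccccc3)cc(=O)c2c1O` carries one acetyl on an oxygen and gives 61600 nM in a functional assay on KB 3-1 cells (Homo sapiens) for inhibition, with a stated time of 72 h; a lower number here means a stronger inhibitor, a higher number a weaker inhibitor. Compound 2 `CC(=O)Oc1cc2oc(-c3ccccc3)cc(=O)c2c(O)c1OC(C)=O` adds a second acetyl, and in this assay compound 2 gives 69300 nM. The step of a 1.1-fold higher number from compound 1 to compound 2 (0.05 log units; within the scatter) shows that this change made no difference that the assay could resolve, so compound 2 and compound 1 stand within the scatter of each other on the two numbers shown. Compound 3 `CC(=O)Oc1cc2oc(-c3ccccc3)cc(=O)c2c(O)c1OCc1ccccc1` differs from compound 2 by benzyl in place of acetyl on an oxygen on an aromatic ring. Going by the values given here, no measured step concerns a benzyl; the single step at hand, from compound 1 to compound 2, was within the scatter. Lacking any step beyond the scatter, the account expects compound 3 to change little, an estimated step of a 1.2-fold lower number from compound 2 to compound 3 (0.06 log units; within the scatter). Compound 3 is therefore estimated at 60000 nM in this assay, with an expected range from 20000 nM to 180000 nM.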

Compound 3, half-maximal inhibitory concentration: 18300 nM
Beside the measured number, compound 3's estimate is 3.3-fold (0.52 log units) above it, and the stated range ends above it.
By their numbers in this assay, from the lowest: compound 3; then compounds 1 and 2 (each within the scatter of the next).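

In this assay, going by these compounds alone, the swap of acetoxy to benzyloxy gives the first step that the assay can resolve, with a 3.8-fold lower number from compound 2 to compound 3 (0.58 log units; beyond the scatter) lying beyond the scatter, though modest in size. The earlier step, which put an acetyl on another oxygen and read a 1.1-fold higher number from compound 1 to compound 2 (0.05 log units; within the scatter), had shown no such movement, so the group on this oxygen can shift the number where that addition did not. Nothing available accounts for the shift.

The change brings in a six-membered aromatic ring of carbon only and removes a carbonyl at once, and these three compounds cannot separate the two. From the compounds shown here alone, whether a plain methyl, a longer alkyl chain, a benzyl ring carrying an amine or a carboxylic acid on this oxygen would move the number further remains open.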